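This account rests on a few compounds, and the source may have more. Where it says the series, first, only, none or still open, it means among the compounds named here.

Of the compounds shown here, three built around a closely related core have been tested in a functional assay on MCF7 cells (Homo sapiens) for inhibition, read by MTT assay, with a stated time of 72 h; a lower number here means a stronger inhibitor, a higher number a weaker inhibitor. There, compound 1 `CO[C@@H]1[C@H]2OC(=O)C[C@H]2O[C@@H]1C(=O)c1ccccc1` gives 3440 nM, compound 2 `O=C1C[C@H]2O[C@H](C(O)O)[C@H](O)[C@H]2O1` gives 9240 nM, and compound 3 `CO[C@@H]1[C@H]2OC(=O)C[C@H]2O[C@@H]1[C@H](O)c1ccccc1` gives 4040 nM. Compound 3 stands within the usual scatter of compound 1, so those two cannot be told apart on these numbers. Compound 2 is furthest from compound 3, with a higher number that lies beyond the scatter.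

The next compound to be tested is compound 4 `CO[C@@H]1[C@H]2OC(=O)C[C@H]2O[C@@H]1[C@H](OC)c1ccccc1`, which differs from compound 3 in one place: methyl in place of hydrogen on an oxygen on a saturated carbon. In words, a methyl takes the place of hydrogen on an oxygen on a saturated carbon, turning hydroxy to methoxy.

Going by the values given here, no pair of measured compounds differs in just one place, so the data contain no direct precedent for this change. The expectation therefore rests on how close the values are, with compound 3 at 4040 nM and compound 1 at 3440 nM. The expected step, a 1.1-fold lower number from compound 3 to compound 4 (0.03 log units; within the scatter), is estimated to stay within the scatter, with no firm direction. For compound 4 the estimated value in this assay is 3800 nM, with an expected range of 1800 nM to 8000 nM.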

Compound 4, half-maximal inhibitory concentration: > 100000 nM
Compound 4 was reported as a limit; the forecaster's own chance of this, stated with the estimate: 3%; at least 26-fold (1.42 log units) between middle value and limit.
By their numbers in this assay, from the lowest: compounds 1 and 3 (each within the scatter of the next); then compound 2. At a limit, above all of these: compound 4.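

Turning hydroxy to methoxy on this saturated carbon gives, in this assay, an at least 24-fold higher number from compound 3 to compound 4 (1.39 log units; beyond the scatter), the first step in the series that changes one place only, and it is large. Compound 4 is reported only as a limit, not as a number: the limit of > 100000 nM in this assay, at which 1 of the 4 values shown sits. The earlier compounds shown here gave no reading of this position, and this result shows that it is not indifferent to change: here a single methyl, one heavy atom in place of the hydrogen on the oxygen, is enough to take the reading in this assay to that limit.

The compounds shown do not separate the loss of the hydrogen from the arrival of the methyl, and since the value for compound 4 is a limit, the true size of the step stays open. An ethyl or an acetyl on this oxygen, or an amine in place of the hydroxy, would show whether any other group is tolerated at this position or whether the free hydroxy alone keeps the reading within measurable range.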